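Chain extension on the sulfur-bound alkyl: ethyl to propyl

The source may hold more compounds than are shown below. What is called first, only, known or untested is meant among the compounds shown, and "the series" means these compounds.

Compound 2 `CCSc1nnc(Cc2ccc(Cl)cc2Oc2ccccc2Cl)[nH]1` gives 174% in a functional assay on the whole organism (strain NMRI) with Mus musculus as the target, with a stated time of 60 min, at a dose of 20 mg/kg by the intraperitoneal route; a higher number here means a stronger effect of the compound at the dose given, a lower number a weaker effect; compound 1 `CSc1nnc(Cc2ccc(Cl)cc2Oc2ccccc2Cl)[nH]1` gives 170% in this assay, and the two values lie within the scatter of each other. Compound 3 `CCCSc1nnc(Cc2ccc(Cl)cc2Oc2ccccc2Cl)[nH]1` differs from compound 2 by methyl in place of hydrogen on a saturated chain carbon, two bonds along the chain from a sulfur. Among the compounds with values here, the one step that bears on it, a number 4 percentage points higher from compound 1 to compound 2 (within the scatter), lengthened the same chain by one carbon and produced no change beyond the scatter. A step of similar size is therefore expected for compound 3, a number 1 percentage points higher from compound 2 to compound 3 (within the scatter), with no direction beyond the scatter. Compound 3 is estimated at 175%, within 150% to 200%.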

Compound 3, a percentage reported as activity, at one dose (the size of the read-out at that dose, not a potency): 134%
Compound 3: the middle estimate sits 41 percentage points above what was measured, and the stated range ends above it.
By their numbers in this assay, from the lowest: compound 3; then compounds 1 and 2 (each within the scatter of the next).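

In this assay, the position on the sulfur-bound chain proves sensitive to chain length: the methyl added two bonds along the chain from the sulfur gives a number 40 percentage points lower from compound 2 to compound 3 (beyond the scatter), and the propylsulfanyl compound also stands apart from its methylsulfanyl counterpart, a number 36 percentage points lower from compound 1 to compound 3 (beyond the scatter). The earlier step between the two shorter chains showed no such separation. No measurement on hand accounts for the drop. As far as these compounds go, whether a butyl chain would extend the fall remains open, as does whether a branched isopropyl group on the sulfur would behave like propyl.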